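A few compounds are considered here, and "the series" means these few. Any claim that something is new, unique, unknown or untested is made for them only; others in the source may bear on it.

Measured compounds in a functional assay on NCI-H460 cells (Homo sapiens) for cytotoxicity, read by MTT assay; a lower number here means a stronger inhibitor, a higher number a weaker inhibitor:
compound 1 `Cc1cccc(Nc2nc(C)c(C(=O)/C=C/c3ccccc3Cl)s2)c1`: > 25000 nM
compound 2 `Cc1ccc(Nc2nc(C)c(C(=O)/C=C/c3ccc(Cl)cc3)s2)cc1`: > 25000 nM
compound 3 `Cc1nc(Nc2ccccc2)sc1C(=O)/C=C/c1ccccc1Cl`: > 25000 nM

In this assay compound 3 gives > 25000 nM, which is a limit of the assay and not a number. Compound 1 gives > 25000 nM, also a limit. Compound 2 likewise gives > 25000 nM, a limit. Among the compounds with values here, because of the limit of > 25000 nM in this assay, at which 3 of the 3 values shown sit, no compound in the set has a measured number, and nothing places compound 3 relative to the other two.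

The change to compound 4 `Cc1ccc(Nc2nc(C)c(C(=O)/C=C/c3ccccc3Cl)s2)cc1` is methyl in place of hydrogen on an aromatic carbon. Within the data shown here, the single measured step of this kind runs the other way: a step that the two limits leave unreadable from compound 1 to compound 3. Its size cannot be read, since both ends are limits. Among the measured compounds shown here, compound 2 also carries methyl in place of hydrogen on an aromatic carbon, but differs from compound 4 elsewhere and no step between them is counted; its value shows only a limit. Nothing measured therefore shows the methyl moving the read-out, and the expectation is that compound 4 stays where the three measured compounds sit: the step that the limit leaves unreadable from compound 3 to compound 4 is expected to be none beyond the scatter. Compound 4 is estimated at 40000 nM (range 15000 nM to 120000 nM), most probably reported again only as a limit.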

Compound 4, half-maximal inhibitory concentration: > 25000 nM
Compound 4: no number, only a limit; the forecaster's own chance of this, stated with the estimate: 85%; the middle value does not contradict the limit.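

In this assay compound 4 gives > 25000 nM, a limit and not a number. No step from compound 1, compound 2 or compound 3 to compound 4 can be read: the limit of > 25000 nM in this assay, at which 4 of the 4 values shown sit.

The compounds shown leave open whether phenyl to 4-methylphenyl, or any other change among them, moves the read-out at all.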